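Piperazine amide series: pyrrolidinyl for sec-butyl at the amine carbon

The compounds below may be only part of what the source reports. "The series", "measured", "known", "first", "only" and "open" are said of these compounds alone.

Three members of this series have numbers in an assay on HEK293 cells for displacement of a labelled ligand from Melanocortin receptor 4 (Homo sapiens); a lower number here means a stronger inhibitor, a higher number a weaker inhibitor. Compound 1 `CCC(C)[C@H](N)c1cc(C(F)(F)F)ccc1N1CCN(C(=O)CCc2ccc(OC)c(OC)c2Cl)CC1` gives 2500 nM, compound 2 `CC(C)C[C@H](N)c1cc(C(F)(F)F)ccc1N1CCN(C(=O)CCc2cccc(C(F)(F)F)c2)CC1` gives 2200 nM, and compound 3 `CCC(C)CN[C@H](c1cc(C(F)(F)F)ccc1N1CCN(C(=O)CCc2ccc(Cl)cc2Cl)CC1)C(C)CC` gives 2800 nM. Compound 3 has the highest of the three numbers, yet its gaps to compound 1 and to compound 2 both fall within the scatter, so no order among them can be drawn.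

Compound 4 `CCC(C)[C@H](NC[C@@H]1CCCN1)c1cc(C(F)(F)F)ccc1N1CCN(C(=O)CCc2ccc(Cl)cc2Cl)CC1` differs from compound 3 in one place: pyrrolidin-2-yl in place of sec-butyl on a saturated chain carbon bound to an amine nitrogen. For the measured compounds named here, no measured pair shows this change, so its size is unknown. Given that compound 3 gives 2800 nM, a lower number for compound 4 is expected, by a step of a 3.5-fold lower number from compound 3 to compound 4 (0.54 log units; beyond the scatter). Compound 4 is therefore estimated at 800 nM, with a range of 200 nM to 3000 nM.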

Compound 4, inhibition constant: 64 nM
Estimate against measurement, compound 4: 13-fold (1.10 log units) above; the whole stated range lies above it.
By their numbers in this assay, from the lowest: compound 4; then compounds 2, 1 and 3 (each within the scatter of the next).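

In this assay, pyrrolidin-2-yl in place of sec-butyl on a saturated chain carbon bound to an amine nitrogen gives a 44-fold lower number from compound 3 to compound 4 (1.64 log units; beyond the scatter). For the compounds shown here, this is the first single-place step, and it shows that the group at this position can move the number far beyond the scatter. No supporting data tie the step to any one feature of the change.

From the compounds shown here alone, whether cyclopentyl, which keeps a five-membered ring but has no ring nitrogen, or an open-chain aminobutyl group would give a similar step remains open. The effect of the opposite configuration at the pyrrolidine stereocentre is also unresolved.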